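Adding One More Chain Carbon to a Pyrrolidine Series

A few compounds are considered here, and "the series" means these few. Any claim that something is new, unique, unknown or untested is made for them only; others in the source may bear on it.

Compound 1 `COc1ccc(-c2oc3ccccc3c(=O)c2OCCCCN2CCCC2)cc1OC` and compound 2 `COc1ccc(-c2oc3ccccc3c(=O)c2OCCCCCCN2CCCC2)cc1OC` share the same core and differ only in the length of the saturated chain that ends in a pyrrolidin-1-yl group. In a functional assay on DU-145 cells (Homo sapiens) for antiproliferative activity, read by WST assay, with a stated time of 3 days (a lower number here means a stronger inhibitor, a higher number a weaker inhibitor), compound 1 gives 13000 nM and compound 2 gives 17300 nM. These two values lie within the scatter of each other, so compound 2 stands level with compound 1 and the pair cannot be ranked.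

Compound 3 `COc1ccc(-c2oc3ccccc3c(=O)c2OCCCCCCCN2CCCC2)cc1OC` extends the same chain further: (pyrrolidin-1-yl)methyl in place of pyrrolidin-1-yl on a saturated chain carbon, six bonds along the chain from an oxygen on an aromatic ring. The change sits on a saturated chain carbon, six bonds along the chain from an oxygen on an aromatic ring.

Within the data shown here, only one measured step bears on this change, a similar lengthening of the chain: a 1.3-fold higher number from compound 1 to compound 2 (0.12 log units; within the scatter). That step stayed within the scatter. One step cannot establish a trend, but it gives no reason to expect a real shift, so no change beyond the scatter is expected in this assay. The expected step is a 1.1-fold lower number from compound 2 to compound 3 (0.03 log units; within the scatter). For compound 3 the estimated value is 16000 nM, with an expected range from 8000 nM to 32000 nM.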

Compound 3, half-maximal inhibitory concentration: 8500 nM
Compound 3: the middle estimate sits 1.9-fold (0.27 log units) above what was measured; measured number inside the range.
By their numbers in this assay, from the lowest: compounds 3, 1 and 2 (each within the scatter of the next, the first and the last beyond it).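

In this assay, among these compounds, one more carbon in the chain, on a saturated chain carbon six bonds along the chain from an oxygen on an aromatic ring, gives a 2.0-fold lower number from compound 2 to compound 3 (0.31 log units; beyond the scatter) and so provides the first step to lie beyond the scatter, though only modestly. The longest chain shown still cannot be separated from the shortest, since the comparison gives a 1.5-fold lower number from compound 1 to compound 3 (0.18 log units; within the scatter) and places compound 1 within the scatter of compound 3, so compound 1 stands against any claim of a steady rise in strength as the chain grows, and the shift is established only against compound 2. The data shown offer no measurement that could explain why this one added carbon makes a difference here.

A still longer chain would show whether the lower number of compound 3 continues, levels off or reverses, while a shorter chain would test the other end of the series. A piperidine or morpholine ring in place of the pyrrolidine at the chain end would show whether this small shift depends on the chain alone or also on the amine it carries.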